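Acylhydrazone series: amino-hydroxyphenyl in place of fluoro-hydroxyphenyl

The source may hold more compounds than are shown below. What is called first, only, known or untested is meant among the compounds shown, and "the series" means these compounds.

For the measured compounds named here, compound 2 `C/C(=N\NC(=O)c1cccc(S(=O)(=O)N2CCOCC2)c1)c1cc(F)ccc1O` holds the lowest of the two numbers so far in a functional assay on MGC-803 cells (Homo sapiens) for antiproliferative activity, read by MTT assay, with a stated time of 72 h; a lower number here means a stronger inhibitor, a higher number a weaker inhibitor; compound 2 gives 2260 nM. Going by the values given here, its only neighbour, compound 1 `C/C(=N\NC(=O)c1cccc(S(=O)(=O)N2CCOCC2)c1)c1cc(Br)ccc1O`, gives 18000 nM, and the single step between them is an 8.0-fold lower number from compound 1 to compound 2 (0.90 log units; beyond the scatter), a halogen exchange on an aromatic carbon.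

Compound 3 `C/C(=N\NC(=O)c1cccc(S(=O)(=O)N2CCOCC2)c1)c1cccc(N)c1O` is not yet measured. Against compound 2 the change is 3-amino-2-hydroxyphenyl in place of 5-fluoro-2-hydroxyphenyl on a carbon with a double bond to nitrogen. Among the compounds with values here, no measured step bears on an amino group or on this rearranged substitution pattern; the one step known, an 8.0-fold lower number from compound 1 to compound 2 (0.90 log units; beyond the scatter), concerns fluoro against bromo and says nothing about an exchange of fluorine for an amino group. The direction of the step is therefore undetermined, and the expectation rests on compound 2 alone, with wide uncertainty on both sides.

For compound 3 the expected step is a 1.8-fold higher number from compound 2 to compound 3 (0.25 log units; within the scatter), a small shift close to the scatter. For compound 3 the estimate in this assay is 4000 nM, with a range from 800 nM to 20000 nM.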

Compound 3, half-maximal inhibitory concentration: 530 nM
The estimate for compound 3 lay 7.5-fold (0.88 log units) above the measured number, outside the stated range (below it).
By their numbers in this assay, from the lowest: compound 3; then compound 2; then compound 1.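

In this assay, the aryl group on the carbon with a double bond to nitrogen accepts a non-halogen substituent, and 3-amino-2-hydroxyphenyl gives the strongest compound of the three: a 4.3-fold lower number from compound 2 to compound 3 (0.63 log units; beyond the scatter), and, against the bromo member, a 34-fold lower number from compound 1 to compound 3 (1.53 log units; beyond the scatter). The earlier halogen exchange showed only a preference between two halogens at one place on the ring, whereas this change swaps the substituent and also moves it, as the two group names show, so the step belongs to the combined change and not to either part alone. No measurement at hand accounts for this gain.

The compounds shown leave open whether the amino group itself or its different place on the ring carries the step, and whether a methylamino or acetamido group would keep the lower number. Also open, on these data alone, is whether the hydroxy group is still needed alongside the amino group, as all three compounds carry it and a methoxy group in its stead would test this.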